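Trifluoromethyl for Phenyl: Estimating Growth Inhibition of Compound 3

This account rests on a few compounds, and the source may have more. Where it says the series, first, only, none or still open, it means among the compounds named here.

compound 1 `CC(=O)c1cccc(Nc2ccnc(SCC(=O)c3ccc(-c4ccccc4)cc3)n2)c1`: 22%
compound 2 `CC(=O)c1ccc(Nc2ccnc(SCC(=O)c3ccc(-c4ccccc4)cc3)n2)cc1`: 11%

In a functional assay on NCI-H226 cells (Homo sapiens) for inhibition, read by sulforhodamine B assay, with a stated time of 48 h, tested at 10 uM (a higher number here means more inhibition of growth at the concentration tested, a lower number less inhibition of growth), compound 1 gives 22%, the highest of the two numbers shown. Compound 2 sits nearest, and the step of a number 11 percentage points lower from compound 1 to compound 2 (beyond the scatter) is a modest one. Compound 3 `CC(=O)c1cccc(Nc2ccnc(SCC(=O)c3ccc(C(F)(F)F)cc3)n2)c1` has not been measured; it differs from compound 1 by trifluoromethyl in place of phenyl on an aromatic carbon. Among the measured compounds shown here, the only measured step concerns the ring on the nitrogen, not this aromatic carbon, so no measured step bears directly on the change. Without guidance the expected step is small, a number 6 percentage points lower from compound 1 to compound 3 (within the scatter), and compound 3 is estimated at 16%, expected to lie between 0% and 35%.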

Compound 3, percent growth inhibition at one concentration: 24%
Estimate against measurement, compound 3: 8 percentage points below; low and high end bracket the measured number.
By their numbers in this assay, from the lowest: compound 2; then compounds 1 and 3 (each within the scatter of the next).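

In this assay, the aromatic carbon that carries phenyl in compound 1 accepts a group without a ring: trifluoromethyl in place of phenyl gives a number 2 percentage points higher from compound 1 to compound 3 (within the scatter). The outer phenyl ring is therefore not required at this position for the growth inhibition seen at the concentration tested. Nothing available explains this result.

As far as these compounds go, whether an amine or a carboxylic acid on this carbon would give a similar number remains open. So does whether the same exchange would read alike with the 4-acetylphenyl of compound 2.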